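The source may hold more compounds than are shown below. What is called first, only, known or untested is meant among the compounds shown, and "the series" means these compounds.

Measured in a functional assay on HCT-116 cells (Homo sapiens) for antiproliferative activity, read by MTT assay, with a stated time of 72 h; on this read-out lower numbers stand for stronger inhibition and higher numbers for weaker inhibition:
Compound 1 `Cc1ccc(-c2cn(C/C=C3\OC(=O)C(OCc4ccccc4)=C3OCc3ccccc3)nn2)cc1`: > 100000 nM, a limit of the assay, not a number.
Compound 2 `O=C1O/C(=C\Cn2cc(-c3cc(C(F)(F)F)cc(C(F)(F)F)c3)nn2)C(OCc2ccccc2)=C1OCc1ccccc1`: > 100000 nM, likewise a limit.
Compound 3 `CCCCCCCCCCc1cn(C[C@H](O)[C@H]2OC(=O)C(OCc3ccccc3)=C2OCc2ccccc2)nn1`: 28800 nM.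

Going by the values given here, compound 3 carries the only numerical value in this assay. The other two values are limits, both sitting at the limit of > 100000 nM in this assay, at which 2 of the 3 values shown sit. Compound 4 `Cc1ccc(S(=O)(=O)NCc2cn(C[C@H](O)[C@H]3OC(=O)C(OCc4ccccc4)=C3OCc3ccccc3)nn2)cc1` is obtained from compound 3 by the change (((4-methylphenyl)sulfonyl)amino in place of nonyl on a saturated chain carbon bound to an aromatic carbon). Among the compounds with values here, no pair of measured compounds differs in a single place, so the size of this step has no precedent within the set. Given that compound 3 is the sole compound returning a number, and that both remaining compounds reach only the limit, compound 4 is expected to land weaker, with a fair chance of a limit. The step is estimated as a 2.1-fold higher number from compound 3 to compound 4 (0.32 log units; beyond the scatter). Compound 4 is expected at 60000 nM, within 20000 nM to 200000 nM.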

Compound 4, half-maximal inhibitory concentration: 13100 nM
For compound 4 the middle estimate is 4.6-fold (0.66 log units) above the measured one; the whole stated range lies above it.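

In this assay replacing nonyl with ((4-methylphenyl)sulfonyl)amino on a saturated chain carbon bound to an aromatic carbon gives a 2.2-fold lower number from compound 3 to compound 4 (0.34 log units; beyond the scatter) and so a modest gain. This position therefore accepts a group with a six-membered aromatic ring and a hydrogen-bond donor in place of a plain alkyl chain, without loss of activity. The data shown give no cause for this step.

As far as these compounds go, whether a simple amine or a carboxylic acid at this position would give a lower number remains open. A single step also cannot show whether the sulfonyl or the aromatic ring carries the change.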